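Cyclopropyl for propyl on the triazole: a cytotoxicity estimate

A few compounds are considered here, and "the series" means these few. Any claim that something is new, unique, unknown or untested is made for them only; others in the source may bear on it.

Compound 1, `COc1nc2ccc(Br)cc2cc1C(c1ccccc1)n1cc(-c2ccc(Br)cc2)nn1`: 6.28%
Compound 2, `CCCc1cn(C(c2ccccc2)c2cc3cc(Br)ccc3nc2OC)nn1`: 0.85%

Both compounds were tested in an ADME assay on HEK293 cells (Homo sapiens) for cytotoxicity, read by sulforhodamine B assay, with a stated time of 48 h, tested at 10 uM; on this read-out higher numbers stand for more inhibition at the one concentration tested (going by the name of the read-out) and lower numbers for less inhibition. Compound 2 stands next to compound 1 on the numbers shown: the step of a number 5.4 percentage points lower from compound 1 to compound 2 (within the scatter) does not reach beyond the scatter, so the two values cannot be told apart. Compound 3, `COc1nc2ccc(Br)cc2cc1C(c1ccccc1)n1cc(C2CC2)nn1`, has not yet been measured. It differs from compound 2 by cyclopropyl in place of propyl on an aromatic carbon. Among the measured compounds shown here, the only measured step, from compound 1 to compound 2, swapped a 4-bromophenyl for a propyl and moved the number by an amount inside the scatter; it bears on the new change only loosely, as the groups exchanged are not the same. For the measured compounds named here, no step in this set has reached beyond the scatter, so compound 3 is expected to give a number close to compound 2, a step of about a number 2.2 percentage points higher from compound 2 to compound 3 (within the scatter). The estimate for compound 3 is 3%, with a range from -7% to 13%.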

Compound 3, a percentage reported as inhibition, at one concentration (the size of the read-out at that concentration, not a potency): 8.22%
Estimate against measurement, compound 3: 5.2 percentage points below; low and high end bracket the measured number.
By their numbers in this assay, from the lowest: compounds 2, 1 and 3 (each within the scatter of the next).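

In this assay, a closed ring is now set against an open chain of the same heavy-atom count on this aromatic carbon: cyclopropyl in place of propyl gives a number 7.4 percentage points higher from compound 2 to compound 3 (within the scatter), so closing the chain into a three-membered ring makes no readable difference here. Cyclopropyl in place of 4-bromophenyl gives a number 1.9 percentage points higher from compound 1 to compound 3 (within the scatter), which means that none of the three groups tried at this position can be told apart from the others on this read-out. No measurement shown explains these numbers.

As far as these compounds go, whether any group on this carbon can move the number beyond the scatter stays open; an amine, a carboxylic acid or a longer chain would be a further test. Changes elsewhere on the shared core also remain an open question.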